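Branching the Benzimidazole Substituent: From Butyl to Tert-Butyl

The compounds below may be only part of what the source reports. "The series", "measured", "known", "first", "only" and "open" are said of these compounds alone.

Of the compounds shown here, three sharing one core have been measured in an assay on membranes from HEK293 cells for displacement of a labelled ligand from Type-2 angiotensin II receptor (Homo sapiens), read by radioligand binding; a higher number here means a weaker inhibitor, a lower number a stronger inhibitor. Compound 1 `CCCCOC(=O)NS(=O)(=O)c1ccc(CCC)cc1-c1ccc(Cn2c(C(C)C)nc3ccccc32)cc1` gives 4 nM. Compound 2 `CCCCOC(=O)NS(=O)(=O)c1ccc(CCC)cc1-c1ccc(Cn2c(-c3ccccc3)nc3ccccc32)cc1` gives 590 nM. Compound 3 `CCCCOC(=O)NS(=O)(=O)c1ccc(CCC)cc1-c1ccc(Cn2c(CCCC)nc3ccccc32)cc1` gives 9.2 nM, which places it second highest of the three numbers, close to compound 1 and far from compound 2.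

The steps among them differ in one place only. The change a 150-fold higher number from compound 1 to compound 2 (2.17 log units; beyond the scatter) is large. The change a 2.3-fold higher number from compound 1 to compound 3 (0.36 log units; beyond the scatter) is modest, and the change a 64-fold lower number from compound 2 to compound 3 (1.81 log units; beyond the scatter) is large in the opposite direction.

Compound 4 `CCCCOC(=O)NS(=O)(=O)c1ccc(CCC)cc1-c1ccc(Cn2c(C(C)(C)C)nc3ccccc32)cc1` differs from compound 3 by tert-butyl in place of butyl on an aromatic carbon. For the measured compounds named here, no measured step exchanges butyl for tert-butyl directly, but the two steps from compound 1 bear on it: isopropyl and butyl give numbers of the same order, while phenyl alone is far off. Tert-butyl is expected to behave like these two alkyl groups rather than like phenyl, so the expected step is a 1.5-fold lower number from compound 3 to compound 4 (0.19 log units; within the scatter), small and within or near the scatter. Compound 4 is therefore estimated at 6 nM, within a range from 2 nM to 25 nM.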

Compound 4, inhibition constant: 5.3 nM
The estimate for compound 4 lay 1.1-fold (0.05 log units) above the measured number; measured number inside the range.
By their numbers in this assay, from the lowest: compounds 1, 4 and 3 (each within the scatter of the next, the first and the last beyond it); then compound 2.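

Rearranging the same four carbons from a straight butyl chain into a tert-butyl group on the aromatic carbon between two ring nitrogen atoms barely registers in this assay (a 1.7-fold lower number from compound 3 to compound 4 (0.24 log units; within the scatter)), so this position does not distinguish the straight chain from the fully branched group. Adding one methyl to the isopropyl group also stays within the scatter (a 1.3-fold higher number from compound 1 to compound 4 (0.12 log units; within the scatter)), while the phenyl group remains well apart from this new alkyl group (a 110-fold lower number from compound 2 to compound 4 (2.05 log units; beyond the scatter)), leaving the three alkyl compounds together and compound 2 alone. Nothing measured here explains the gap between these alkyl groups and phenyl.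

From the compounds shown here alone, whether a small methyl, a saturated ring such as cyclohexyl, or a chain ending in an amine would stay with the alkyl compounds or fall towards compound 2 remains open. A longer chain such as octyl would test how much size this position accepts.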